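Expected effect of methoxy in compound 3

A few compounds are considered here, and "the series" means these few. Any claim that something is new, unique, unknown or untested is made for them only; others in the source may bear on it.

In a functional assay on NCI-H522 cells (Homo sapiens) for cytotoxicity, with a stated time of 3 days (a lower number here means a stronger inhibitor, a higher number a weaker inhibitor), compound 1 (`C#Cc1nc(C(=O)Nc2ccc(Cl)cc2)cs1`) gives 540 nM and compound 2 (`C#Cc1nc(C(=O)Nc2ccccc2)cs1`) gives 660 nM. These two values lie within the scatter of each other, so compound 2 cannot be separated from compound 1 on the numbers available.

Next in the series is compound 3 (`C#Cc1nc(C(=O)Nc2ccc(OC)cc2)cs1`), which differs from compound 2 as follows: methoxy in place of hydrogen on an aromatic carbon. The change is methoxy in place of hydrogen on an aromatic carbon, para to a large group.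

For the measured compounds named here, only one measured step bears on this change: a 1.2-fold higher number from compound 1 to compound 2 (0.09 log units; within the scatter), with hydrogen in place of chloro on an aromatic carbon. That step lies within the scatter. Going by the values given here, no measured compound carries methoxy, so the data give no direction for the new group, and no shift beyond the scatter is expected. The estimated step is a 1.1-fold lower number from compound 2 to compound 3 (0.03 log units; within the scatter), expected to remain within the scatter. In this assay compound 3 is expected at 620 nM, with an estimated range of 260 nM to 1500 nM.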

Compound 3, half-maximal inhibitory concentration: 670 nM
Estimate against measurement, compound 3: 1.1-fold (0.03 log units) below; measured number inside the range.
By their numbers in this assay, from the lowest: compounds 1, 2 and 3 (each within the scatter of the next).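

In this assay the series now holds three groups on this aromatic carbon, para to a large group: hydrogen, chloro and methoxy. For the compounds shown here, the new group, which brings an oxygen atom and a hydrogen-bond acceptor, gives a 1.0-fold higher number from compound 2 to compound 3 (0.01 log units; within the scatter) and a 1.2-fold higher number from compound 1 to compound 3 (0.09 log units; within the scatter) and so stays within the scatter on both steps, where the earlier compounds offered only the one comparison of chloro with hydrogen. Compound 1, compound 2 and compound 3 therefore cannot be separated on their numbers, and nothing measured here speaks to why this substitution leaves the read-out within the scatter.

The compounds shown leave open whether any group at this place can move the number beyond the scatter, for instance an amine, a carboxylic acid or a longer chain such as butoxy. They also leave open whether the shared core outside this aromatic ring, including the amide hydrogen and the carbonyl, is equally insensitive to change, since all three compounds keep that part the same.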